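From Methylsulfonyl to Dimethylcarbamoyl on a Weak Binder

The compounds below may be only part of what the source reports. "The series", "measured", "known", "first", "only" and "open" are said of these compounds alone.

Of the compounds shown here, three built on one shared core have been measured in an assay on CHO-K1 cells for antagonist activity at adenosine receptor A1 (Homo sapiens), read by a beta-galactosidase reporter, with stated times of 15 min and 6 h; on this read-out higher numbers stand for weaker inhibition and lower numbers for stronger inhibition. Compound 1, `Nc1nc(-c2ccco2)nc2sc(CN3CCC(O)CC3)cc12`, gives 4000 nM in this assay. Compound 2, `Nc1nc(-c2cccc(C(F)(F)F)c2)nc2sc(CN3CCC(F)CC3)cc12`, gives 3030 nM. Compound 3, `CS(=O)(=O)c1cccc(-c2nc(N)c3cc(CN4CCC(F)CC4)sc3n2)c1`, returned only the limit of the assay and not a number: it gives > 10000 nM. Of the three, compound 3 is the one for which only a limit is known, the ceiling described by the limit of > 10000 nM in this assay, at which 1 of the 3 values shown sits. Among the measured compounds shown here, the single measured step between neighbours, an at least 3.3-fold higher number from compound 2 to compound 3 (0.51 log units; beyond the scatter), carried the number past that ceiling.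

Compound 4, `CN(C)C(=O)c1cccc(-c2nc(N)c3cc(CN4CCC(F)CC4)sc3n2)c1`, differs from compound 3 in one place: dimethylcarbamoyl in place of methylsulfonyl on an aromatic carbon. For the measured compounds named here, no measured step covers a swap of this kind, so the only guide is that the one measured change at this position, an at least 3.3-fold higher number from compound 2 to compound 3 (0.51 log units; beyond the scatter), weakened inhibition and left compound 3 at the limit. With a new group entering at the same place, compound 4 is expected to remain in the same weak region, with an estimated step of a number no higher from compound 3 to compound 4 (the limit leaves the size open). The estimate for compound 4 is therefore 10000 nM, expected to fall between 3000 nM and 30000 nM, and a further limit reading is the more likely outcome.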

Compound 4, inhibition constant: > 10000 nM
Compound 4: no number, only a limit; the forecaster's own chance of this, stated with the estimate: 60%; the middle value sits exactly at the limit.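

In this assay, the loss of inhibition at this position is no longer tied to methylsulfonyl alone, since replacing trifluoromethyl with dimethylcarbamoyl also gives a clear weakening, an at least 3.3-fold higher number from compound 2 to compound 4 (0.51 log units; beyond the scatter). Compounds 3 and 4 each return only a limit and not a number, so the step between them cannot be read and neither group can be ranked against the other. Two different groups on this aromatic carbon now leave the read-out at the top of its range, and the ceiling is reached often among the results shown: the limit of > 10000 nM in this assay, at which 2 of the 4 values shown sit.

The compounds shown leave open whether any other group at this place, such as a nitrile, a methoxy group, an amine or a carboxylic acid, would bring the number back below the limit. They also leave open how far beyond the limit compound 3 and compound 4 truly lie, and whether either group would behave the same way on a compound with stronger inhibition.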